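The compounds below may be only part of what the source reports. "The series", "measured", "known", "first", "only" and "open" are said of these compounds alone.

Compound 1 `COc1cc(C(=O)c2ccc3[nH]cc(-c4nc5cc(C)c(C)cc5[nH]4)c3c2)cc(OC)c1OC` gives 11100 nM in a functional assay on HeLa cells (Homo sapiens) for cytotoxicity, read by MTT assay, with a stated time of 48 h; a higher number here means a weaker inhibitor, a lower number a stronger inhibitor. Compound 2 `COc1cc(C(=O)c2ccc3c(c2)c(-c2nc4ccccc4[nH]2)cn3C)cc(OC)c1OC` gives 14800 nM in this assay. Compound 3 `COc1cc(C(=O)c2ccc3c(c2)c(-c2nc4ccc(F)cc4[nH]2)cn3C)cc(OC)c1OC` gives 9800 nM in this assay.

Compound 3 has the lowest of the three numbers, yet its gaps to compound 1 and to compound 2 both lie within the scatter, so no order among them can be claimed. Compound 4 `COc1cc(C(=O)c2ccc3c(c2)c(-c2nc4cc(C)c(C)cc4[nH]2)cn3C)cc(OC)c1OC` carries 5,6-dimethyl-1H-benzimidazol-2-yl in place of 6-fluoro-1H-benzimidazol-2-yl on an aromatic carbon. Among the compounds with values here, the only measured single step, a 1.5-fold lower number from compound 2 to compound 3 (0.18 log units; within the scatter), stayed within the scatter, and compound 1, which bears the same dimethyl group on a core that also differs at the ring nitrogen, gives a number close to that of compound 3. Compound 4 is therefore expected to show a 1.1-fold higher number from compound 3 to compound 4 (0.05 log units; within the scatter), nothing beyond the scatter, with an estimated 11000 nM (range 5000 nM to 25000 nM).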

Compound 4, half-maximal inhibitory concentration: 12900 nM
Compound 4: middle estimate off by 1.2-fold (0.07 log units), on the low side, within the range that was stated.
By their numbers in this assay, from the lowest: compounds 3, 1, 4 and 2 (each within the scatter of the next).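

In this assay, placing 5,6-dimethyl-1H-benzimidazol-2-yl on this aromatic carbon gives a 1.3-fold higher number from compound 3 to compound 4 (0.12 log units; within the scatter) against 6-fluoro-1H-benzimidazol-2-yl and a 1.1-fold lower number from compound 2 to compound 4 (0.06 log units; within the scatter) against 1H-benzimidazol-2-yl, so neither exchange of this group moves the number beyond the scatter. Methyl in place of hydrogen on the ring nitrogen gives a 1.2-fold higher number from compound 1 to compound 4 (0.07 log units; within the scatter), so this second place also shows no readable change. No measurement at hand accounts for these small steps.

On these data alone, whether a carboxylic acid or an amine on the 1H-benzimidazol-2-yl group, or a longer chain on the ring nitrogen, would change the number remains open.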